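A few compounds are considered here, and "the series" means these few. Any claim that something is new, unique, unknown or untested is made for them only; others in the source may bear on it.

Compound 1 `CCS(=O)(=O)Nc1cc(-c2ccc3ncnc(Nc4cccc(F)c4)c3c2)cnc1OC`: 2760 nM
Compound 2 `CCS(=O)(=O)Nc1cc(-c2ccc3ncnc(Nc4ccc(OC)c(Cl)c4)c3c2)cnc1OC`: 2470 nM

In a functional assay on BT-549 cells (Homo sapiens) for cytotoxicity, read by sulforhodamine B assay, with a stated time of 72 h (a higher number here means a weaker inhibitor, a lower number a stronger inhibitor), compound 2 gives the lower of the two numbers, but the step of a 1.1-fold lower number from compound 1 to compound 2 (0.05 log units; within the scatter) sits within the scatter, so the two compounds cannot be told apart. Compound 3 `CCS(=O)(=O)Nc1cc(-c2ccc3ncnc(Nc4ccc(F)c(C(=O)OC)c4)c3c2)cnc1OC` differs from compound 2 by 4-fluoro-3-(methoxycarbonyl)phenyl in place of 3-chloro-4-methoxyphenyl on a nitrogen on an aromatic ring. Among the compounds with values here, the only comparable step, a 1.1-fold lower number from compound 1 to compound 2 (0.05 log units; within the scatter), also swapped the group on that nitrogen and moved nothing beyond the scatter, so no step beyond the scatter is expected: a 1.1-fold higher number from compound 2 to compound 3 (0.02 log units; within the scatter). Compound 3 is therefore estimated at 2600 nM in this assay, within 1000 nM to 7000 nM.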

Compound 3, half-maximal inhibitory concentration: 2740 nM
For compound 3 the middle estimate is 1.1-fold (0.02 log units) below the measured one; low and high end bracket the measured number.
By their numbers in this assay, from the lowest: compounds 2, 3 and 1 (each within the scatter of the next).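

In this assay, both a 1.1-fold higher number from compound 2 to compound 3 (0.05 log units; within the scatter) and a 1.0-fold lower number from compound 1 to compound 3 (0.00 log units; within the scatter) stay within the scatter. So the three groups on this nitrogen cannot be told apart, even though 4-fluoro-3-(methoxycarbonyl)phenyl brings a carbonyl and more heavy atoms than either earlier group. Nothing available explains why these swaps leave the number within the scatter.

From the compounds shown here alone, whether an amine or a carboxylic acid in place of the methoxycarbonyl group would give a step beyond the scatter remains open. So does whether changes elsewhere on the shared core would matter more than changes at this position.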